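Notes on adding a 2-fluorobenzyl group to compound 1

This account rests on a few compounds, and the source may have more. Where it says the series, first, only, none or still open, it means among the compounds named here.

The series is followed in a functional assay on Bel-7402 cells (Homo sapiens) for antiproliferative activity, read by MTT assay, with a stated time of 72 h; a lower number here means a stronger inhibitor, a higher number a weaker inhibitor. Compound 1 (`C=C1C(=O)O[C@H]2[C@H]1CC/C(COC(=O)Cn1cc(F)c(=O)[nH]c1=O)=C\CC[C@@]1(C)O[C@@H]21`) gives > 20000 nM here, which is a limit and not a number. Compound 2 (`C=C1C(=O)O[C@H]2[C@H]1CC/C(Cn1cc(Cn3cc(F)c(=O)[nH]c3=O)nn1)=C\CC[C@@]1(C)O[C@@H]21`) gives > 20000 nM, again a limit. Compound 1 therefore stands at the limit of > 20000 nM in this assay, at which 2 of the 3 values shown sit, and has no numerical read-out. Within the data shown here, compound 3 (`C=C1C(=O)O[C@H]2[C@H]1CC/C(COC(=O)CCC(=O)NCCCCCCNC(=O)Cn1cc(F)c(=O)n(Cc3ccccc3)c1=O)=C\CC[C@@]1(C)O[C@@H]21`), the only measured compound with a benzyl group on that aromatic nitrogen, gives 18300 nM as a real number.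

Compound 4 (`C=C1C(=O)O[C@H]2[C@H]1CC/C(COC(=O)Cn1cc(F)c(=O)n(Cc3ccccc3F)c1=O)=C\CC[C@@]1(C)O[C@@H]21`) places 2-fluorobenzyl in place of hydrogen on an aromatic nitrogen of compound 1, as counted in 2-fluorobenzyl in place of hydrogen on an aromatic nitrogen. Among the measured compounds shown here, no measured pair isolates this change, so the expectation in this assay is a small move toward stronger inhibition, on the evidence that compound 3 gives 18300 nM and not a limit. The expected step is an at least 1.4-fold lower number from compound 1 to compound 4 (0.15 log units; that floor lies within the scatter) and a further limit result remains possible. Compound 4 is estimated at 14000 nM, with an expected range from 5000 nM to 30000 nM.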

Compound 4, half-maximal inhibitory concentration: 3770 nM
Beside the measured number, compound 4's estimate is 3.7-fold (0.57 log units) above it; measured number below the stated range.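

Putting 2-fluorobenzyl in place of hydrogen on this aromatic nitrogen gives an at least 5.3-fold lower number from compound 1 to compound 4 (0.72 log units; beyond the scatter) in this assay. The position therefore accepts a substituent carrying one six-membered aromatic ring, and the hydrogen on that nitrogen is not required for activity in this series. The true size of the step remains unknown, as its starting point is a limit and not a number: the limit of > 20000 nM in this assay, at which 2 of the 4 values shown sit.

The compounds shown leave open whether the benzyl ring alone or its fluoro group carries the step, and a plain benzyl or a 4-fluorobenzyl group at the same place would separate the two. They also leave open how a smaller methyl, an amine or a carboxylic acid on a longer chain would read on this nitrogen of compound 1.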